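Swapping the aryl amine on a weakly active series

The source may report more compounds than this note shows. Statements on the series, on what has been measured and on what is new or still open speak of the compounds shown alone.

The set holds three measured compounds and one awaiting measurement. Compound 1 `O=C(CSc1nc(Nc2ccccc2)c2ccccc2n1)Nc1ccccc1F` gives, in a functional assay on MDA-MB-231 cells (Homo sapiens) for inhibition, read by MTT assay, with a stated time of 72 h (on this read-out higher numbers stand for weaker inhibition and lower numbers for stronger inhibition), only a limit of the assay, > 50000 nM. Compound 2 `O=C(CSc1nc(Nc2ccccc2)c2ccccc2n1)Nc1cccc([N+](=O)[O-])c1` gives 33000 nM in this assay. Compound 3 `C=CC(=O)Nc1cccc(NC(=O)CSc2nc(Nc3ccccc3Br)c3ccccc3n2)c1` gives 15200 nM, the lowest of the two numbers shown, with compound 2 the nearest at a gap beyond the scatter. Going by the values given here, the one step recorded between measured compounds, an at least 1.5-fold lower number from compound 1 to compound 2 (0.18 log units; that floor lies within the scatter), concerns the amide-type nitrogen and is bounded by the limit of > 50000 nM in this assay, at which 1 of the 3 values shown sits; it says nothing about the nitrogen on the aromatic ring that is altered next.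

Compound 4 `C=CC(=O)Nc1cccc(NC(=O)CSc2nc(Nc3ccc(C(F)(F)F)cc3)c3ccccc3n2)c1` differs from compound 3 by 4-(trifluoromethyl)phenyl in place of 2-bromophenyl on a nitrogen on an aromatic ring. Among the compounds with values here, no measured step touches this position, so no direction can be read from the data. Compound 4 is therefore expected to sit near compound 3, with a step of a 1.0-fold lower number from compound 3 to compound 4 (0.01 log units; within the scatter) within the scatter, and its estimated value in this assay is 15000 nM, in a range from 5000 nM to 50000 nM.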

Compound 4, half-maximal inhibitory concentration: 11500 nM
The estimate for compound 4 lay 1.3-fold (0.12 log units) above the measured number; the measured number falls inside the stated range.
By their numbers in this assay, from the lowest: compounds 4 and 3 (each within the scatter of the next); then compound 2. At a limit, above all of these: compound 1.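

Going by these compounds alone, at the nitrogen on an aromatic ring, the change from 2-bromophenyl to 4-(trifluoromethyl)phenyl gives the first reading for this position in this assay: a 1.3-fold lower number from compound 3 to compound 4 (0.12 log units; within the scatter). The two groups cannot be told apart on this read-out, and neither can be ranked above the other, so this position accepts either group without a change beyond the scatter. Nothing measured here bears on why the two groups read alike.

This single pair changes the substituent and its place on the ring together, and it does not separate the two. Also open, from the compounds shown here alone, is whether a carboxylic acid or a dimethylamino group on this aryl ring would move the number beyond the scatter in this assay.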